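A few compounds are considered here, and "the series" means these few. Any claim that something is new, unique, unknown or untested is made for them only; others in the source may bear on it.

Two compounds from this series share one core and differ only in the group attached to an oxygen on an aromatic ring. Compound 1 `C=C(C)C(=O)NCCOc1ccc(Oc2c(-c3ccc(F)cc3)sc3cc(O)ccc23)cc1` carries an open chain there. In a functional assay on MCF7 cells (Homo sapiens) for antiproliferative activity, read by CCK-8 assay, with a stated time of 48 h (on this read-out higher numbers stand for weaker inhibition and lower numbers for stronger inhibition), compound 1 gives > 25000 nM, which is a limit of this assay rather than a number. Compound 2 `O=C(/C=C/CN1CC(Oc2ccc(Oc3c(-c4ccc(F)cc4)sc4cc(O)ccc34)cc2)C1)N1CCC1` carries a ring-bearing group in the same place. In this assay compound 2 gives > 25000 nM, again a limit. Both measured values therefore sit at the same point, (the limit of > 25000 nM in this assay, at which 2 of the 2 values shown sit), so compound 1 cannot be placed above or below its neighbour.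

The unmeasured compound 3 `C=C(C)C(=O)N1CC(Oc2ccc(Oc3c(-c4ccc(F)cc4)sc4cc(O)ccc34)cc2)C1` is made from compound 1 by the change (1-((1-methylethenyl)carbonyl)azetidin-3-yl in place of 2-(((1-methylethenyl)carbonyl)amino)ethyl on an oxygen on an aromatic ring). Among the compounds with values here, no measured step shows what such a change does here, so the expected step from compound 1 to compound 3, a number no higher from compound 1 to compound 3 (the limit leaves the size open), is taken as no change beyond the scatter. On that basis compound 3 is expected to give about 25000 nM in this assay, with a likely range from 6000 nM to 60000 nM.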

Compound 3, half-maximal inhibitory concentration: > 25000 nM
Compound 3: no number, only a limit (the forecaster's own chance of this, stated with the estimate: 65%); the middle value sits exactly at the limit.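

In this assay compound 3 gives > 25000 nM, which is a limit and not a number. No step among compound 1, compound 2 and compound 3 can therefore be read: the limit of > 25000 nM in this assay, at which 3 of the 3 values shown sit.

From the compounds shown here alone, whether these three compounds differ at all in this assay remains open.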